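Compound 3: ethylsulfonyl on the amide-type nitrogen

The source may report more compounds than this note shows. Statements on the series, on what has been measured and on what is new or still open speak of the compounds shown alone.

Measured in an ADME assay on MT4 cells (Homo sapiens) for cytotoxicity, read by MTT assay, with a stated time of 5 days; on this read-out higher numbers stand for lower toxicity in this test and lower numbers for higher toxicity in this test:
Compound 1 `Cc1cc(C)cc(S(=O)(=O)c2c(C(=O)N[C@H]3CCN(CC(N)=O)C3)[nH]c3ccc(Cl)cc23)c1`: 28100 nM
Compound 2 `Cc1cc(C)cc(S(=O)(=O)c2c(C(=O)NC3CN(Cc4ccccc4F)C3)[nH]c3ccc(Cl)cc23)c1`: > 238000 nM, a limit

Compound 2 gives > 238000 nM, which is a limit of the assay and not a number. Its exact standing in this assay is therefore unknown.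

Compound 3 `CCS(=O)(=O)NC(=O)c1[nH]c2ccc(Cl)cc2c1S(=O)(=O)c1cc(C)cc(C)c1` has not yet been measured. It has ethylsulfonyl in place of 1-(2-fluorobenzyl)azetidin-3-yl on an amide-type nitrogen. Here the carbonyl carbon is the other neighbour of that nitrogen.

Going by the values given here, only one measured step bears on this change: an at least 8.4-fold higher number from compound 1 to compound 2 (0.92 log units; beyond the scatter). That step lies beyond the scatter and introduced the very group that compound 3 gives up. Among the compounds with values here, it is a single step, and ethylsulfonyl itself has no measured precedent here, so the guidance is loose. A drop to a lower number, of broadly similar size to that step, is expected. The expected change is an at least 4.7-fold lower number from compound 2 to compound 3 (0.67 log units; beyond the scatter). For compound 3 the estimate is 50000 nM, with an expected range of 12000 nM to 200000 nM.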

Compound 3, half-maximal cytotoxic concentration: > 283000 nM
Compound 3 was reported as a limit (the forecaster's own chance of this, stated with the estimate: 30%); middle value at least 5.6-fold (0.75 log units) away from the limit.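

In this assay compound 3 gives > 283000 nM, which is a limit of the assay and not a number. The step between compound 2 and compound 3 cannot be read: both values are limits. What compound 3 adds is that the reading at this amide-type nitrogen does not depend on 1-(2-fluorobenzyl)azetidin-3-yl, since ethylsulfonyl, with no ring and fewer heavy atoms, also ends at a limit and gives an at least 10-fold higher number from compound 1 to compound 3 (1.00 log units; beyond the scatter). Among the three compounds, 1-(carbamoylmethyl)pyrrolidin-3-yl in compound 1 is thus the only group here that gives a measured number, and it stands against both compounds that end at limits.

The compounds shown leave open whether the lower number of compound 1 goes with its carbamoylmethyl group or with its pyrrolidine ring, a question that the plain pyrrolidin-3-yl group or a 1-(2-fluorobenzyl)pyrrolidin-3-yl group could address. They also leave open whether a longer chain on the sulfonyl, such as butylsulfonyl, or a free primary amine on this nitrogen's substituent would stay at a limit or give a number.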